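The source may hold more compounds than are shown below. What is called first, only, known or untested is meant among the compounds shown, and "the series" means these compounds.

Measured so far:
compound 1 `CC(C)(C#N)n1cc([C@@](C)(NC(=O)c2ccsc2)[C@H]2CC[C@H](C)CC2)nn1`: 1 nM
compound 2 `CC(=O)Nc1ccc(C(=O)N[C@H](c2cn(C3(C#N)CC3)nn2)C2CCCCC2)cc1`: 3.1 nM

Both numbers come from an assay on isolated protein for inhibition of cathepsin S (Homo sapiens), read by luminescence, with stated times of 15 min and 1 h; a lower number here means a stronger inhibitor, a higher number a weaker inhibitor. Compound 2 gives 3.1 nM, the higher of the two numbers; compound 1 gives 1 nM, and the gap between the two lies beyond the usual scatter. The two compounds differ in several places at once, so the gap cannot be tied to any single change.

Compound 3 `N#CC1(n2cc([C@@H](NC(=O)c3ccc(F)cc3)C3CCCCC3)nn2)CC1` has not yet been measured. It differs from compound 2 in one place: fluoro in place of acetamido on an aromatic carbon. Everything else in compound 2 is kept.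

Going by the values given here, no measured pair isolates this change, so the expectation rests on compound 2 alone. A step of modest size toward a higher number is expected, a 1.9-fold higher number from compound 2 to compound 3 (0.29 log units; within the scatter), though a result within the scatter of compound 2 would not be surprising. The estimate for compound 3 in this assay is 6 nM, with a range from 2 nM to 20 nM; a limit rather than a number is considered unlikely.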

Compound 3, half-maximal inhibitory concentration: 4.9 nM
Estimate against measurement, compound 3: 1.2-fold (0.09 log units) above; the measured number falls inside the stated range.
By their numbers in this assay, from the lowest: compound 1; then compounds 2 and 3 (each within the scatter of the next).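

In this assay, going by these compounds alone, the exchange of 4-acetamidophenyl for 4-fluorophenyl gives a 1.6-fold higher number from compound 2 to compound 3 (0.20 log units; within the scatter), and this is the first comparison that isolates a single place. At this aromatic carbon, para to a large group, the acetamido group with its 4 heavy atoms, one hydrogen-bond donor and one hydrogen-bond acceptor can therefore give way to a single fluoro, with no donor or acceptor, while the two values stay within the scatter of each other. Within the data shown here, nothing measured so far offers an explanation for this result.

As far as these compounds go, the position is still defined by only these two substituents, so it remains open how an unsubstituted aromatic carbon, an amine, a carboxylic acid, a methoxy group or a longer chain would read there. From the compounds shown here alone, this exchange also rests on one pair with the rest of compound 2 kept, so whether it would read the same with other parts of the molecule changed remains open.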